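The source may hold more compounds than are shown below. What is called first, only, known or untested is meant among the compounds shown, and "the series" means these compounds.

Compound 1 `Cc1cc(CNCc2ccc(Cl)cc2)c(C)n1-c1ccc(Cl)cc1`: 0.1 ug/mL
Compound 2 `Cc1cc(CNCc2ccccc2)c(C)n1-c1ccc(F)cc1`: 5.6 ug/mL

In an ADME assay on RAW264.7 cells (Mus musculus) for cytotoxicity, read by trypan blue exclusion, with a stated time of 48 h (a higher number here means a weaker inhibitor of growth, a lower number a stronger inhibitor of growth), compound 2 gives 5.6 ug/mL, the higher of the two numbers and well beyond the usual scatter from compound 1. Compound 3 `Cc1cc(CNCc2ccccc2)c(C)n1-c1ccc(Cl)cc1` differs from compound 2 in one place: chloro in place of fluoro on an aromatic carbon. Among the compounds with values here, no measured pair isolates this change. Compound 1, at 0.1 ug/mL, also carries the 4-chlorophenyl but differs from compound 2 in a second place, so only part of that gap may carry over. A moderate fall in the number is expected, a 3.7-fold lower number from compound 2 to compound 3 (0.57 log units; beyond the scatter). For compound 3, the estimate is 1.5 ug/mL, with an expected range of 0.3 ug/mL to 7 ug/mL.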

Compound 3, concentration for 50% growth inhibition: 5.5 ug/mL
Beside the measured number, compound 3's estimate is 3.7-fold (0.56 log units) below it; measured number inside the range.
By their numbers in this assay, from the lowest: compound 1; then compounds 3 and 2 (each within the scatter of the next).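

In this assay, the halogen on the 4-fluorophenyl to 4-chlorophenyl change makes no readable difference, with a 1.0-fold lower number from compound 2 to compound 3 (0.01 log units; within the scatter) as the step. The chloro on the other aromatic ring carries far more weight: replacing it with hydrogen gives a 55-fold higher number from compound 1 to compound 3 (1.74 log units; beyond the scatter) in the same assay, and this holds only for this pair of compounds. Still open, going by these compounds, is whether a methoxy group or a trifluoromethyl group at the first position would also leave the number unchanged, and whether a fluoro or methyl group in place of the second chloro would keep the number low. No supporting data explain either result.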